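Changing One Group on a Lone Measured Compound

This account rests on a few compounds, and the source may have more. Where it says the series, first, only, none or still open, it means among the compounds named here.

Within the data shown here, compound 1 `COc1ccc(C2CC(Nc3nc4ccc(Cl)cc4s3)=NN2C(C)=O)cc1O` is the only compound here with a number in a functional assay on the whole organism (strain albino) with Mus musculus as the target, with a stated time of 0.5 h (a higher number here means that more compound is needed for the effect, a lower number that less compound is needed), where compound 1 gives 132 umol/kg. With nothing to set beside it, that figure cannot yet be called high or low. Compound 2 `COc1ccc(C2CC(Nc3nc4ccccc4s3)=NN2C(C)=O)cc1O` offers no comparison, since the entry for compound 2 reads "not determined" (no result reported).

Compound 3 `CC(=O)N1N=C(Nc2nc3ccc(Cl)cc3s2)CC1c1ccc(Cl)cc1` keeps the core of compound 1 but carries 4-chlorophenyl in place of 3-hydroxy-4-methoxyphenyl on a saturated ring carbon. Among the measured compounds shown here, no pair of measured compounds shows what a change like this does in this assay, so the data give neither its size nor its direction. For the measured compounds named here, the only anchor is compound 1 at 132 umol/kg, and the sensible starting expectation is a result close to it, with a wide margin on both sides. The expected change is a 1.1-fold lower number from compound 1 to compound 3 (0.04 log units; within the scatter), a step not expected to exceed the usual scatter of repeated measurements. Compound 3 is estimated at 120 umol/kg, with an expected range from 40 umol/kg to 360 umol/kg.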

Compound 3, dose for half-maximal effect: 81.5 umol/kg
The estimate for compound 3 lay 1.5-fold (0.17 log units) above the measured number, within the range that was stated.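

Placing 4-chlorophenyl in place of 3-hydroxy-4-methoxyphenyl on a saturated ring carbon gives, in this assay, a 1.6-fold lower number from compound 1 to compound 3 (0.21 log units; within the scatter), so the two compounds cannot be told apart in this measurement. Among these compounds, this is the first pair with a number on both sides, and it shows that this position can take a different substituted phenyl group without a step beyond the scatter, even though the hydrogen-bond donor and acceptors counted on the leaving group are absent from the entering one. Nothing at hand explains this result.

Among the compounds shown here, a single step covers only one exchange, and in it the hydroxy and methoxy groups leave while the chlorine enters, so the part played by each remains unknown. Also open, going by these compounds, is whether a quite different group at this position, such as an amine or a carboxylic acid on the phenyl ring, or a longer alkyl chain in place of the ring, would likewise stay within the scatter or would move the dose needed for the effect clearly in one direction.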